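Trifluoromethyl Addition on Two Related Dienone Cores

The source may hold more compounds than are shown below. What is called first, only, known or untested is meant among the compounds shown, and "the series" means these compounds.

Compound 1 `CC1=CCCC(C)(C)C1/C=C/C(=O)/C=C/c1ccccc1F`: 8300 nM
Compound 2 `CC1=CCCC(C)(C)C1/C=C/C(=O)/C=C/c1cc(C(F)(F)F)ccc1F`: 3000 nM
Compound 3 `CC1=C(/C=C/C(=O)/C=C/c2ccc(F)cc2)C(C)(C)CCC1O`: "not determined" (no result reported)

In a functional assay on PCa 2b cells (Homo sapiens) for cytotoxicity, read by MTT assay, with a stated time of 72 h (on this read-out lower numbers stand for stronger inhibition and higher numbers for weaker inhibition), compound 1 gives 8300 nM and compound 2 gives 3000 nM. The change between them is trifluoromethyl in place of hydrogen on an aromatic carbon, and it produced a 2.8-fold lower number from compound 1 to compound 2 (0.44 log units; beyond the scatter). For compound 3 the result is "not determined" (no result reported). Compound 4 `CC1=C(/C=C/C(=O)/C=C/c2ccc(F)c(C(F)(F)F)c2)C(C)(C)CCC1O` differs from compound 3 by trifluoromethyl in place of hydrogen on an aromatic carbon; this is the same kind of change as from compound 1 to compound 2, but the entering group sits ortho to a fluoro group rather than para to it. The difference between the core of compound 1 and the core of compound 3 is not broken down here. As far as these compounds go, because a 2.8-fold lower number from compound 1 to compound 2 (0.44 log units; beyond the scatter) was modest, a similar modest step is expected for compound 4, though with no result for compound 3 the starting point is unknown. Compound 4 is estimated at 4000 nM, within 1000 nM to 16000 nM.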

Compound 4, half-maximal inhibitory concentration: 10000 nM
For compound 4 the middle estimate is 2.5-fold (0.40 log units) below the measured one, and the stated range covers the measured number.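

With no result for compound 3 in this assay, the step from compound 3 to compound 4 cannot be read. As far as these compounds go, what trifluoromethyl changes on the core of compound 3 stays open, and no evidence here bears on the result.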